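A few compounds are considered here, and "the series" means these few. Any claim that something is new, unique, unknown or untested is made for them only; others in the source may bear on it.

In an assay on isolated protein for inhibition of NUAK family SNF1-like kinase 2 (Homo sapiens), read by ADP-Glo, with a stated time of 60 min, tested at 10 uM, in the presence of a further agent that is not named here (a lower number here means less inhibition, a higher number more inhibition at the concentration tested (going by the name of the read-out)), compound 1 `CCC(=O)Nc1cccc(Oc2nc(Nc3ccc(N4CCCCC4)cc3)ncc2Cl)c1` gives 72.3%. Compound 2 `CCC(=O)Nc1cccc(Oc2nc(Nc3ccc(N4CCC(C)CC4)cc3OC)ncc2Cl)c1` is reported in this assay as "not active" (no number reported), so no single number places it on the scale. Compound 3 `CCC(=O)Nc1cccc(Oc2nc(Nc3ccc(N4CCC(C)CC4)cc3)ncc2Cl)c1` differs from compound 2 by hydrogen in place of methoxy on an aromatic carbon. Compound 1, which also lacks the methoxy group, reaches 72.3% in this assay, so the step from compound 2 to compound 3 is expected to run toward more inhibition, by an amount well beyond the usual scatter. For compound 3 the inhibition in this assay is estimated near 55%, within a range from 20% to 85%.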

Compound 3, a percentage reported as inhibition, at one concentration (the size of the read-out at that concentration, not a potency): 24.8%
Compound 3: middle estimate off by 30.2 percentage points, on the high side, within the range that was stated.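

The methoxy group alone does not decide the result: without it, compound 3 gives 24.8% in this assay, and the methyl in place of hydrogen on a saturated ring carbon accounts for a number 47.5 percentage points lower from compound 1 to compound 3 (beyond the scatter). The step from compound 2 to compound 3 cannot be read, since compound 2 has no number. Nothing shown here explains the size of the drop from that methyl. The compounds shown leave open how a hydroxyl or an ethyl group on that saturated ring carbon would compare. They also leave open what a fluorine in place of the methoxy would do.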